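The source may report more compounds than this note shows. Statements on the series, on what has been measured and on what is new or still open speak of the compounds shown alone.

Measured so far in a physicochemical assay for solubility, in phosphate buffer, measured as kinetic solubility; on this read-out lower numbers stand for lower solubility and higher numbers for higher solubility:
- Compound 1 `CC(C)C(c1ccc(-c2ccc3cccc(F)c3c2)[nH]c1=O)C1SC(=O)NC1=O`: 20100 nM
- Compound 2 `C/C(=C1/OC(=O)NC1=O)C(c1ccc(-c2ccc3cccc(F)c3c2)[nH]c1=O)C(C)C`: 17200 nM

Compound 2, at 17200 nM, lies within the scatter of compound 1, so the two numbers cannot be told apart. Compound 3 `CC(C)C(c1ccc(-c2ccc3cccc(F)c3c2)[nH]c1=O)C1C(=O)NC(=O)N1C` has not yet been measured. The change leading to it is a group of 8 heavy atoms (4 carbon, 2 nitrogen, 2 oxygen; one five-membered non-aromatic ring with 2 hetero atoms) in place of a group of 9 heavy atoms (5 carbon, 1 nitrogen, 3 oxygen; one five-membered non-aromatic ring with 2 hetero atoms), on a saturated chain carbon bound to an aromatic carbon and a saturated chain carbon. The entering group is 3-methyl-2,5-dioxoimidazolidin-4-yl, on a saturated chain carbon bound to an aromatic carbon and a saturated chain carbon.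

Among the compounds with values here, only one measured step bears on this change: a 1.2-fold lower number from compound 1 to compound 2 (0.07 log units; within the scatter). It also swaps one group with a five-membered non-aromatic ring with 2 hetero atoms for another at the same place. Within the data shown here, this single step is a thin basis, and no measured compound yet carries the entering group. On the evidence of a 1.2-fold lower number from compound 1 to compound 2 (0.07 log units; within the scatter), no change beyond the scatter is expected in this assay. The expected step is a 1.0-fold higher number from compound 2 to compound 3 (0.02 log units; within the scatter). For compound 3 the estimated value is 18000 nM, with an expected range of 8000 nM to 40000 nM.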

Compound 3, solubility: 17900 nM
Beside the measured number, compound 3's estimate is 1.0-fold (0.00 log units) above it; the range from low to high includes it.
By their numbers in this assay, from the lowest: compounds 2, 3 and 1 (each within the scatter of the next).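

In this assay, 3-methyl-2,5-dioxoimidazolidin-4-yl adds a third group to the comparison at this place, with a 1.0-fold higher number from compound 2 to compound 3 (0.02 log units; within the scatter) and a 1.1-fold lower number from compound 1 to compound 3 (0.05 log units; within the scatter). The series now holds three different groups, each with a five-membered non-aromatic ring with 2 hetero atoms, on a saturated chain carbon bound to an aromatic carbon and a saturated chain carbon, and compounds 1, 2 and 3 cannot be told apart in this assay. Heavy-atom count, double bonds outside aromatic rings and hydrogen-bond acceptors all differ between the group that leaves and the group that enters, yet neither new step lies beyond the scatter, and no independent measurement is available to account for these numbers.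

Every group shown at this place carries the same type of ring, so the outcome for an open-chain group such as a carboxylic acid or an amine remains unknown. As far as these compounds go, the rest of the molecule is also shared by all three compounds, so it remains open whether these groups would still be indistinguishable in this assay on a different core.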